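The source may report more compounds than this note shows. Statements on the series, on what has been measured and on what is new or still open speak of the compounds shown alone.

Compound 1 `Cc1cccc2sc(NC(=O)COc3ccc(/C=C4\SC(=O)NC4=O)cc3)nc12` sits at the limit of a functional assay on KB cells (Homo sapiens) for inhibition (a higher number here means a weaker inhibitor of growth, a lower number a stronger inhibitor of growth), giving > 100000 nM. Compound 3 `O=C(COc1ccc(/C=C2\SC(=O)NC2=O)cc1)Nc1ccc(Cl)cc1C(F)(F)F` likewise returns only the limit, > 100000 nM. Within the data shown here, compound 2 `O=C(COc1ccc(/C=C2\SC(=O)NC2=O)cc1)Nc1ccc(Cl)cc1` is the sole compound with an actual number in this assay, 50300 nM. Compound 4 `O=C(COc1ccc(/C=C2\SC(=O)NC2=O)cc1)Nc1c(Cl)cccc1Cl` differs from compound 2 by 2,6-dichlorophenyl in place of 4-chlorophenyl on an amide-type nitrogen. The one measured step that alters the same ring, an at least 1.9-fold higher number from compound 2 to compound 3 (0.29 log units; that floor lies within the scatter), is a floor rather than a full size, as shown by the limit of > 100000 nM in this assay, at which 2 of the 3 values shown sit. On that thin basis the change is expected to push the number upward, a 2.0-fold higher number from compound 2 to compound 4 (0.30 log units; within the scatter). Compound 4 is therefore estimated at 100000 nM, within 40000 nM to 300000 nM, with a real chance that this assay reports only its limit.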

Compound 4, concentration for 50% growth inhibition: > 100000 nM
Compound 4 gave a limit, no number (the forecaster's own chance of this, stated with the estimate: 55%); the middle value sits exactly at the limit.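

In this assay, 2,6-dichlorophenyl in place of 4-chlorophenyl on the amide-type nitrogen gives an at least 1.9-fold higher number from compound 2 to compound 4 (0.29 log units; that floor lies within the scatter). That step is a floor, so its full size cannot be read. Compound 4 is now the second compound, after compound 3, in which a change to this ring leaves no number to set against compound 2, and the assay's ceiling now holds most of the data: the limit of > 100000 nM in this assay, at which 3 of the 4 values shown sit.

Still open, from the compounds shown here alone, is whether a ring carrying an amine or a carboxylic acid in place of chlorine would give a real number in this assay. Going by these compounds, whether a plain phenyl would differ from compound 2 is also open.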